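A few compounds are considered here, and "the series" means these few. Any claim that something is new, unique, unknown or untested is made for them only; others in the source may bear on it.

Compound 1 `N#Cc1cnc2n(COCCO)cnc(N)c1-2` — in an ADME assay on BSC-1 cells (Cercopithecidae) for cytotoxicity (a lower number here means a stronger inhibitor, a higher number a weaker inhibitor), compound 1 gives > 100000 nM, a limit of the assay rather than a number.
Compound 2 `NC(=O)c1cn(COCCO)c2ncnc(N)c12` — in this assay compound 2 gives > 100000 nM, again a limit of the assay.

Compound 2 thus stands at the limit of > 100000 nM in this assay, at which 2 of the 2 values shown sit, so no number is known for it. Compound 3 `NNC(=O)c1cn(COCCO)c2ncnc(N)c12` carries amino in place of hydrogen on an amide-type nitrogen. No step between measured compounds is available; since both shown values sit at the limit, no shift beyond the scatter is expected, and the estimated step is a step that the limit leaves unreadable from compound 2 to compound 3. For compound 3 the expected value is 150000 nM, with a range from 50000 nM to 500000 nM, and most likely only a limit will again be reported.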

Compound 3, half-maximal inhibitory concentration: > 100000 nM
Compound 3 was reported as a limit (the forecaster's own chance of this, stated with the estimate: 85%); the middle value does not contradict the limit.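

No step can be read from compound 2 to compound 3 in this assay, as both results are limits of the assay: the limit of > 100000 nM in this assay, at which 3 of the 3 values shown sit.

The compounds shown leave open whether any of them has a numerical value in this assay.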